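This account rests on a few compounds, and the source may have more. Where it says the series, first, only, none or still open, it means among the compounds named here.

Measured so far: compound 1 `CC(=O)Nc1ccc(NC(=O)C(F)(F)C(F)(F)C(F)(F)C(F)(F)C(F)(F)C(F)(F)C(=O)NO)cc1` gives 9200 nM in an assay on isolated protein for inhibition of protein deacetylase HDAC6 (Homo sapiens), read by fluorescence; on this read-out higher numbers stand for weaker binding and lower numbers for tighter binding; compound 2 `O=C(NO)C(F)(F)C(F)(F)C(F)(F)C(F)(F)C(F)(F)C(F)(F)C(=O)Nc1cccc(-c2ccccc2)c1` gives 15000 nM in this assay.

Compound 1 and compound 2 lie within the scatter of each other, as a 1.6-fold higher number from compound 1 to compound 2 (0.21 log units; within the scatter) shows. Compound 3 `O=C(NO)C(F)(F)C(F)(F)C(F)(F)C(F)(F)C(F)(F)C(F)(F)C(=O)Nc1ccccc1-c1ccccc1` differs from compound 1 by 2-phenylphenyl in place of 4-acetamidophenyl on an amide-type nitrogen. Among the measured compounds shown here, the one measured step that bears on this change is a 1.6-fold higher number from compound 1 to compound 2 (0.21 log units; within the scatter), where 3-phenylphenyl replaced the same 4-acetamidophenyl without moving the number beyond the scatter. A shift of similar size, if any, is therefore expected in this assay. Compound 3 is expected to give 12000 nM, within 4000 nM to 40000 nM. The expected step is a 1.3-fold higher number from compound 1 to compound 3 (0.12 log units; within the scatter).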

Compound 3, dissociation constant: 9200 nM
Beside the measured number, compound 3's estimate is 1.3-fold (0.12 log units) above it; the range from low to high includes it.
By their numbers in this assay, from the lowest: compounds 1, 3 and 2 (each within the scatter of the next).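

In this assay, the step with 2-phenylphenyl in place of 4-acetamidophenyl on an amide-type nitrogen is no change at the digits printed from compound 1 to compound 3 (within the scatter) and so adds a second substituent type that stays level with the acetamide. The step with 2-phenylphenyl in place of 3-phenylphenyl is a 1.6-fold lower number from compound 2 to compound 3 (0.21 log units; within the scatter), which shows that, for these two groups, changing where the second ring sits leaves the number within the scatter. No evidence is available to explain this result.

Going by these compounds, it remains open whether a group on this nitrogen carrying an amine or a carboxylic acid would move the number beyond the scatter. On these data alone, the effect of a longer chain in the shared core is also open.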